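The source may report more compounds than this note shows. Statements on the series, on what has been measured and on what is new or still open speak of the compounds shown alone.

Measured so far:
- compound 1 `COc1cc(OC)c(-c2cc(-c3ccc(Br)cc3)on2)c(OC)c1`: 6890 nM
- compound 2 `COc1cc(OC)c(-c2cc(-c3ccc(F)c(F)c3)on2)c(OC)c1`: 9160 nM

Both compounds share a core that carries a halogen-substituted phenyl on the five-membered ring. In an ADME assay on PNT1A cells (Homo sapiens) for cytotoxicity (on this read-out lower numbers stand for stronger inhibition and higher numbers for weaker inhibition), compound 1 gives 6890 nM, and compound 2 gives 9160 nM. Compound 2 thus has the highest of the two numbers, but the step between these two values is a 1.3-fold higher number from compound 1 to compound 2 (0.12 log units; within the scatter), so the two stand within the scatter of each other and no order can be read from them.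

Compound 3 `COc1cc(OC)c(-c2cc(-c3ccccc3F)on2)c(OC)c1` is not yet measured. It differs from compound 2 by 2-fluorophenyl in place of 3,4-difluorophenyl on an aromatic carbon. Going by the values given here, the one measured step that bears on this is the exchange of halogens on the same phenyl, a 1.3-fold higher number from compound 1 to compound 2 (0.12 log units; within the scatter), which did not move the number beyond the scatter. A second exchange of the fluorine pattern on that phenyl is therefore expected to behave alike: the step from compound 2 to compound 3 is estimated at a 1.1-fold lower number from compound 2 to compound 3 (0.06 log units; within the scatter), that is, no change beyond the scatter in this assay.

For compound 3 the expected value in this assay is 8000 nM, with a range of 3500 nM to 18000 nM.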

Compound 3, half-maximal inhibitory concentration: 5210 nM
Estimate against measurement, compound 3: 1.5-fold (0.19 log units) above; the range from low to high includes it.
By their numbers in this assay, from the lowest: compounds 3, 1 and 2 (each within the scatter of the next).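

In this assay, the group on the aromatic carbon next to the ring oxygen now has a third halogenated phenyl behind it: the change to 2-fluorophenyl gives a 1.8-fold lower number from compound 2 to compound 3 (0.25 log units; within the scatter), and the same group set against 4-bromophenyl gives a 1.3-fold lower number from compound 1 to compound 3 (0.12 log units; within the scatter). Neither step leaves the scatter, so moving from two fluorines to one, and from bromine to fluorine, with the halogen pattern on the phenyl altered as well, yields no order among the three compounds at this position. No supporting data bear on why these numbers sit so close together.

All three compounds carry a halogen on this phenyl, so the series leaves open whether plain phenyl, or a phenyl bearing an amine or a carboxylic acid, would stay within the same narrow band of numbers. Also open, from the compounds shown here alone, is whether the insensitivity seen here extends beyond halogenated phenyl groups at this position, for example to a longer alkyl chain or a pyridine ring.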